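Working notes: from compound 3 to compound 4

The compounds below may be only part of what the source reports. "The series", "measured", "known", "first", "only" and "open" are said of these compounds alone.

Measured in a functional assay on HepG2 cells (Homo sapiens) for inhibition, read by MTT assay, with a stated time of 72 h; a higher number here means a weaker inhibitor, a lower number a stronger inhibitor:
- compound 1 `Cc1cc2occ(-c3nc(-c4ccccc4)c(-c4ccccc4)n3-c3ccccc3Cl)c(=O)c2cc1Cl` gives 6250 nM
- compound 2 `Cc1cc2occ(-c3nc(-c4ccccc4)c(-c4ccccc4)n3-c3ccc(Br)cc3)c(=O)c2cc1Cl` gives 6250 nM
- compound 3 `Cc1ccc(-n2c(-c3coc4cc(C)c(Cl)cc4c3=O)nc(-c3ccccc3)c2-c2ccccc2)cc1` gives 6250 nM

Level with compounds 1 and 2, compound 3 stands at 6250 nM. The next structure, compound 4 `COc1cccc(-n2c(-c3coc4cc(C)c(Cl)cc4c3=O)nc(-c3ccccc3)c2-c2ccccc2)c1`, carries 3-methoxyphenyl in place of 4-methylphenyl on an aromatic nitrogen.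

Among the compounds with values here, three measured steps bear on this change, and none moves the value beyond the scatter: no change at the digits printed from compound 1 to compound 2 (within the scatter) and no change at the digits printed from compound 1 to compound 3 (within the scatter) and no change at the digits printed from compound 2 to compound 3 (within the scatter). Within the data shown here, no measured compound carries a 3-methoxyphenyl group, so the data do not test that group directly, and three compounds are a narrow base.

Given the flat step no change at the digits printed from compound 2 to compound 3 (within the scatter), no shift beyond the scatter is expected in this assay in either direction. The expected step is no change at the digits printed from compound 3 to compound 4 (within the scatter). For compound 4 the estimate is 6250 nM, with an expected range of 3000 nM to 13000 nM.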

Compound 4, half-maximal inhibitory concentration: 6250 nM
Compound 4: the middle estimate sits on the measured number at the digits printed; the range from low to high includes it.
By their numbers in this assay, from the lowest: compounds 1, 2, 3 and 4 (each within the scatter of the next).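

In this assay, within the data shown here, the aromatic nitrogen now tolerates 3-methoxyphenyl, the first group at this position to carry an oxygen, with no change at the digits printed from compound 3 to compound 4 (within the scatter), no change at the digits printed from compound 2 to compound 4 (within the scatter) and no change at the digits printed from compound 1 to compound 4 (within the scatter). The flat picture seen with 2-chlorophenyl, 4-bromophenyl and 4-methylphenyl therefore extends to a group with a different substituent and a different substituent placement, and all four compounds remain within the scatter of one another. No measurement shown accounts for this flatness.

Going by these compounds, it remains open whether a group of another kind on this nitrogen, such as a simple alkyl chain, an aminoalkyl chain or a phenyl ring bearing a carboxylic acid, would move the value. Since every compound shown keeps the same two phenyl groups and the same chloro and methyl groups on the core, the effect of changing those groups also remains open.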